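Half-life in serum after swapping a chain-end hydroxy for a tert-butyl ester

The compounds below may be only part of what the source reports. "The series", "measured", "known", "first", "only" and "open" are said of these compounds alone.

Measured so far:
compound 1, `Cc1cn(C2CC(N=[N+]=[N-])C(COC(=O)OCCCCCCCCO)O2)c(=O)[nH]c1=O`: 0.0333 h
compound 2, `Cc1cn(C2CC(N=[N+]=[N-])C(COC(=O)NCCCO)O2)c(=O)[nH]c1=O`: > 48 h

In an ADME assay on the whole organism (serum) with Homo sapiens as the target (on this read-out lower numbers stand for a shorter-lived compound and higher numbers for a longer-lived compound), compound 1 gives 0.0333 h. For compound 2 this assay reports only a limit, > 48 h, which marks (the limit of > 48 h in this assay, at which 1 of the 2 values shown sits); its true number lies beyond what the assay resolves. Within the data shown here, the one measured step, an at least 1400-fold higher number from compound 1 to compound 2 (3.15 log units; beyond the scatter), concerns the group on the carbonyl carbon, which compound 3, `Cc1cn(C2CC(N=[N+]=[N-])C(COC(=O)NCCCC(=O)OC(C)(C)C)O2)c(=O)[nH]c1=O`, keeps unchanged from compound 2. Among the measured compounds shown here, the change here is instead (tert-butoxycarbonyl in place of hydroxy on a saturated chain carbon, three bonds along the chain from an amide-type nitrogen), far from the carbonyl, so the one measured step bears on it only indirectly. For compound 3 no step beyond the scatter is expected, an at least 1.2-fold lower number from compound 2 to compound 3 (0.07 log units; that floor lies within the scatter). Compound 3 is therefore estimated at about 40 h, with a plausible range from 8 h to 150 h, with a fair chance that this assay again returns only a limit.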

Compound 3, half-life: > 48 h
Compound 3: a limit, no number; the forecaster's own chance of this, stated with the estimate: 45%; middle value at least 1.2-fold (0.07 log units) from the limit.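

In this assay, compound 2 and compound 3 each return only a limit, so no step between them can be read: the limit of > 48 h in this assay, at which 2 of the 3 values shown sit.

From the compounds shown here alone, how long either compound truly lasts, and whether tert-butoxycarbonyl in place of hydroxy changes that at all, stays open.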